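Changing one stereocentre in a weak vitamin D receptor ligand

The compounds below may be only part of what the source reports. "The series", "measured", "known", "first", "only" and "open" are said of these compounds alone.

Compounds measured so far:
compound 1, `CCCCCCCCOC(C)(C)[C@@H](O)COc1ccc(C(CC)(CC)c2ccc(OC[C@@H](O)CO)c(C)c2)cc1C`, "not active" (no number reported)
compound 2, `CCCCCCCCCCOC(C)(C)[C@@H](O)COc1ccc(C(CC)(CC)c2ccc(OC[C@@H](O)CO)c(C)c2)cc1C`, "not active" (no number reported)
compound 3, `CCCCCCOC(C)(C)[C@H](O)COc1ccc(C(CC)(CC)c2ccc(OC[C@@H](O)CO)c(C)c2)cc1C`, > 10000 nM

In an assay on HEK293 cells for agonist activity at vitamin D3 receptor (Homo sapiens), read by a beta-galactosidase reporter (a lower number here means that less compound is needed, a higher number that more compound is needed for the effect), compound 1 is reported as "not active" (no number reported). In this assay compound 2 is likewise reported as "not active" (no number reported). For compound 3 the result is a limit of the assay rather than a number: in this assay compound 3 gives > 10000 nM. For the measured compounds named here, compound 3 therefore stands at the limit of > 10000 nM in this assay, at which 1 of the 3 values shown sits, and the two other compounds carry no number at all, so no measured step within the group can be stated.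

Compound 4, `CCCCCCOC(C)(C)[C@@H](O)COc1ccc(C(CC)(CC)c2ccc(OC[C@@H](O)CO)c(C)c2)cc1C`, is the unmeasured compound. Its difference from compound 3 is the two compounds have the same atoms and bonds and differ only in configuration as drawn: 1 of 2 stereo elements differ; a stereocentre at a saturated chain carbon is drawn R in compound 3 and S in compound 4. Going by the values given here, since no two measured compounds differ by a single change, the size of this step is unknown. With compound 3 sitting at a limit and compounds 1 and 2 without numbers, the expectation is that compound 4 also gives no active value, and the estimated step from compound 3 to compound 4 is a number no higher from compound 3 to compound 4 (the limit leaves the size open). The estimate for compound 4 in this assay is 10000 nM, expected to fall between 1500 nM and 50000 nM.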

Compound 4, half-maximal effective concentration: 1500 nM
The estimate for compound 4 lay 6.7-fold (0.82 log units) above the measured number; the range from low to high includes it.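

In this assay, for the compounds shown here, redrawing a single stereocentre at a saturated chain carbon from R to S gives an at least 6.6-fold lower number from compound 3 to compound 4 (0.82 log units; beyond the scatter), the first step that can be read in this group. Compound 3 gives > 10000 nM, which is a limit of the assay and not a number. The change in activity can be assigned to the configuration at this one carbon, because nothing else separates the pair: the fact that compounds 3 and 4 differ only in the configuration as drawn

Compounds 1 and 2 share the configuration drawn in compound 4 but carry longer chains. On these data alone, compound 1 is reported as "not active" (no number reported) and compound 2 as "not active" (no number reported), so the favourable configuration appears in these compounds together with a lack of reported activity, and how chain length and configuration work together remains open. The compounds shown also leave open whether a shorter chain at the same ether, or a carboxylic acid in its place, would keep or change the number seen for compound 4, and whether the second stereocentre, in the diol on the other side of the molecule, is as sensitive to redrawing as this one.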